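Oxazole amide series: liver microsome stability, aryl swap

This account rests on a few compounds, and the source may have more. Where it says the series, first, only, none or still open, it means among the compounds named here.

Measured compounds:
- compound 1, `Cc1cc(C)c(-c2nc(CN3CCC(C(=O)NCCCN4C[C@H](C)C[C@H](C)C4)CC3)c(C)o2)c(C)c1`: > 0.5 h
- compound 2, `CC[C@@H]1C[C@H](CC)CN(CCCNC(=O)C2CCN(Cc3nc(-c4c(F)cccc4F)oc3C)CC2)C1`: 0.065 h
- compound 3, `Cc1cccc(Cl)c1-c1nc(CN2CCC(C(=O)NCCCN3CCC(C(C)C)CC3)CC2)c(C)o1`: 0.0333 h

In an ADME assay on microsomes from liver (Rattus norvegicus) for metabolic stability, read by LC-MS, using NADPH, at 37 degrees C (on this read-out higher numbers stand for a longer-lived compound and lower numbers for a shorter-lived compound), compound 1 is reported only as a limit, > 0.5 h; this is the limit of > 0.5 h in this assay, at which 1 of the 3 values shown sits. Compound 2 gives 0.065 h in this assay and compound 3 gives 0.0333 h, both clear numbers well short of where compound 1 sits. Compound 1 thus stands at the upper edge of what is shown, while compound 2 and compound 3 occupy the low end. For the measured compounds named here, no pair among the three differs in a single place, so no measured step is available.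

Compound 4, `COc1cccc(Br)c1-c1nc(CN2CCC(C(=O)NCCCN3C[C@H](C)C[C@H](C)C3)CC2)c(C)o1`, has not been measured. It differs from compound 1 by 2-bromo-6-methoxyphenyl in place of 2,4,6-trimethylphenyl on an aromatic carbon. Since compound 1 is known only as a limit, the step to compound 4 cannot be anchored; a decrease beyond the scatter is expected, though a result at the limit remains possible. In this assay compound 4 is estimated at 0.2 h, within 0.05 h to 0.8 h, an expected step of an at least 2.5-fold lower number from compound 1 to compound 4 (0.39 log units; beyond the scatter).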

Compound 4, half-life: 0.0583 h
Compound 4: middle estimate off by 3.4-fold (0.54 log units), on the high side; low and high end bracket the measured number.
By their numbers in this assay, from the lowest: compounds 3, 4 and 2 (each within the scatter of the next). At a limit, above all of these: compound 1.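

For the compounds shown here, this is the first comparison that differs in one place only: in this assay, 2-bromo-6-methoxyphenyl in place of 2,4,6-trimethylphenyl gives an at least 8.5-fold lower number from compound 1 to compound 4 (0.93 log units; beyond the scatter). The aromatic group on this carbon of the five-membered ring can therefore shift the half-life beyond the scatter on its own, with the rest of the structure of compound 1 unchanged. The printed size is only a lower bound, since compound 1 is reported as a limit: the limit of > 0.5 h in this assay, at which 1 of the 4 values shown sits.

As far as these compounds go, the bromine and the methoxy group enter together and the three methyl groups leave together, so which of these changes carries the step stays open. Also open, from the compounds shown here alone, is how a plain phenyl group, or a phenyl group bearing methoxy alone, would read at this place.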